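A few compounds are considered here, and "the series" means these few. Any claim that something is new, unique, unknown or untested is made for them only; others in the source may bear on it.

Compound 3 `O=C1COc2ccc(-c3cnc4ccccc4c3)cc2N1` gives 26300 nM in a functional assay on HepG2 cells (Homo sapiens) for antiproliferative activity, read by MTT assay, with a stated time of 72 h (on this read-out higher numbers stand for weaker inhibition and lower numbers for stronger inhibition), the lowest of the two numbers in the series. Compound 2 `O=C1COc2ccc(-c3ccc(O)cc3)cc2N1` gives 38200 nM in this assay, within the scatter of compound 3. Compound 1 `O=C1COc2ccc(-c3cnc4ccccc4c3)cc2N1c1ccccc1` reaches only the limit > 40000 nM in this assay. Compound 4 `O=C1COc2ccc(-c3cnc4ccccc4c3)cc2N1c1ccc(F)cc1` differs from compound 3 by 4-fluorophenyl in place of hydrogen on an amide-type nitrogen in a ring. Going by the values given here, the one measured step that bears on this change is an at least 1.5-fold lower number from compound 1 to compound 3 (0.18 log units; that floor lies within the scatter), the reverse of placing an aryl group on the same nitrogen; because compound 1 sits at the limit (the limit of > 40000 nM in this assay, at which 1 of the 3 values shown sits), the true size of that step is unknown. Placing a 4-fluorophenyl group on that nitrogen is therefore expected to raise the number, probably back toward the limit. The expected value for compound 4 in this assay is 45000 nM, in a range of 20000 nM to 100000 nM, an expected step of a 1.7-fold higher number from compound 3 to compound 4 (0.23 log units; within the scatter).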

Compound 4, half-maximal inhibitory concentration: 37200 nM
Compound 4: middle estimate off by 1.2-fold (0.08 log units), on the high side; the measured number falls inside the stated range.
By their numbers in this assay, from the lowest: compounds 3, 4 and 2 (each within the scatter of the next). At a limit, above all of these: compound 1.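

In this assay compound 4 puts a measured number, not a limit, on an aryl group at the amide-type nitrogen, and a 1.4-fold higher number from compound 3 to compound 4 (0.15 log units; within the scatter) shows that 4-fluorophenyl in place of hydrogen there makes no change beyond the scatter. The fluoro change on the aromatic carbon reads only as a floor, an at least 1.0-fold lower number from compound 1 to compound 4 (0.03 log units; that floor lies within the scatter). Compound 1 stands at a limit, so the true size of that step cannot be read: the limit of > 40000 nM in this assay, at which 1 of the 4 values shown sits.

Open, as far as these compounds go, is how a methyl group or an aminoethyl chain on the same nitrogen would read, and whether any group there moves the number beyond the scatter.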